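This account rests on a few compounds, and the source may have more. Where it says the series, first, only, none or still open, it means among the compounds named here.

Compound 1 `O=C(CN(c1nc(Cl)nc2[nH]cnc12)C1CC1)NCC(=O)OCc1ccccc1` gave 21.7% in a functional assay on the whole organism (Tail, strain ICR) with Mus musculus as the target, in the tail flick test, with a stated time of 120 min, at a dose of 25 umol/kg by the oral route; on this read-out lower numbers stand for a weaker effect and higher numbers for a stronger effect at the one dose given.
Compound 2 `C[C@H](NC(=O)CN(c1ncnc2c1ncn2C1CCCCO1)C1CC1)C(=O)OCc1ccccc1` gave 25.3% in this assay.
Compound 3 `CCOC(=O)CN(c1nc(Cl)nc2c1ncn2C1CCCCO1)C1CC1` gave 14.9% in this assay.

Of these three readings, the number of compound 1 lies closest to that of compound 2 and furthest from that of compound 3, yet both gaps fall within the usual scatter of this test, so the three compounds cannot be told apart on the numbers shown. For the measured compounds named here, no pair among them differs in only one place, so no single step can be read from the measured set.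

Compound 4 `O=C(CN(c1nc(Cl)nc2[nH]cnc12)C1CC1)N[C@@H](CO)C(=O)OCc1ccccc1` has not yet been measured in this assay. It differs from compound 1 by one change: hydroxymethyl in place of hydrogen on a saturated chain carbon bound to an amide-type nitrogen and a carbonyl carbon. Going by the values given here, the measured compounds give no step of this kind to lean on. Since the three numbers in hand all sit within the scatter of one another, the step from compound 1 to compound 4 is expected to stay within the scatter as well, a number 1.3 percentage points higher from compound 1 to compound 4 (within the scatter), with no clear direction. Compound 4 is therefore estimated at 23%, in a range from 11% to 36%.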

Compound 4, a percentage reported as activity, at one dose (the size of the read-out at that dose, not a potency): 34.5%
Compound 4: the middle estimate sits 11.5 percentage points below what was measured; measured number inside the range.
By their numbers in this assay, from the lowest: compounds 3, 1, 2 and 4 (each within the scatter of the next, the first and the last beyond it).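

Hydroxymethyl in place of hydrogen on this saturated chain carbon, bound to an amide-type nitrogen and a carbonyl carbon, gives the first single change that can be read in this assay, with a number 12.8 percentage points higher from compound 1 to compound 4 (beyond the scatter). The earlier compounds shown here differed in several places at once, so they could not show that this carbon responds to substitution; this pair shows that it does, and in the upward direction. Nothing available explains the step.

The compounds shown leave open whether the gain is specific to hydroxymethyl or would also appear with a plain methyl, an aminomethyl or a longer chain on the same carbon. On these data alone, the step also rests on a single pair, so whether it carries over to other members remains unknown.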